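The compounds below may be only part of what the source reports. "The series", "measured", "known", "first", "only" and "open" are said of these compounds alone.

an assay on isolated protein for inhibition of activin receptor type-2A (Homo sapiens), read by 33P incorporation, with a stated time of 20 min, in the presence of a further agent that is not named here (a lower number here means a stronger inhibitor, a higher number a weaker inhibitor), has so far been applied to two compounds that share one core. Compound 1 `COc1cc(-c2cnn3cc(OC)c(C4CCOC4)nc23)ccn1` gives 1900 nM. Compound 2 `COc1cc(-c2cnn3cc(OC)c(C)nc23)ccn1`, which carries a methyl in place of the oxolan-3-yl, gives 1200 nM. On these numbers compound 2 stands beside compound 1: the step of a 1.6-fold lower number from compound 1 to compound 2 (0.20 log units; within the scatter) is within the usual scatter, so the two compounds are not told apart. Compound 3 `COc1cc(-c2cnn3cc(OC)c([C@@H]4COC(C)(C)C4)nc23)ccn1` has not yet been measured. It differs from compound 2 in this way: a group of 7 heavy atoms (6 carbon, 1 oxygen; one five-membered non-aromatic ring with 1 hetero atom) in place of one carbon atom, on an aromatic carbon. Among the compounds with values here, the only measured step that bears on this change runs the other way, a methyl in place of a five-membered ring with one hetero atom, and it gave a 1.6-fold lower number from compound 1 to compound 2 (0.20 log units; within the scatter). Restoring a ring of that kind, here a larger one, is therefore expected to move the number little, with at most a slight lean toward a higher number. The expected step is a 1.4-fold higher number from compound 2 to compound 3 (0.15 log units; within the scatter). Compound 3 is estimated at 1700 nM, within 800 nM to 3600 nM.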

Compound 3, half-maximal inhibitory concentration: 5300 nM
Compound 3: middle estimate off by 3.1-fold (0.49 log units), on the low side, and the stated range ends below it.
By their numbers in this assay, from the lowest: compounds 2 and 1 (each within the scatter of the next); then compound 3.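

In this assay, this position turns out not to accept every group equally: placing the larger ring group where methyl stood gives a 4.4-fold higher number from compound 2 to compound 3 (0.65 log units; beyond the scatter), whereas methyl and oxolan-3-yl could not be told apart. The comparison between the two ring groups adds a second point, since a 2.8-fold higher number from compound 1 to compound 3 (0.45 log units; beyond the scatter) shows that having a five-membered non-aromatic ring with 1 hetero atom at this aromatic carbon does not alone set the number, and that the larger group gives the weaker inhibitor. Nothing available explains this loss.

As far as these compounds go, compound 3 has a defined stereocentre, so it remains open whether its mirror-image form would read the same. From the compounds shown here alone, how an amine or a carboxylic acid would behave on this aromatic carbon also remains open.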